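The compounds below may be only part of what the source reports. "The series", "measured", "known", "first", "only" and "open" are said of these compounds alone.

In a functional assay on HT-29 cells (Homo sapiens) for cytotoxicity, read by MTT assay, with a stated time of 72 h (a lower number here means a stronger inhibitor, a higher number a weaker inhibitor), compound 2 (`Cc1ccccc1NC(=O)CN1CCN(c2nnc(Cc3ccccc3)c3ccccc23)CC1`) gives 113000 nM, the highest of the three numbers, against compound 1 (`O=C(CN1CCN(c2nnc(Cc3ccccc3)c3ccccc23)CC1)Nc1c(F)cccc1F`) at 19700 nM and compound 3 (`Cc1ccccc1NC(=O)CN1CCN(c2nnc(Cc3ccncc3)c3ccccc23)CC1`) at 15000 nM. Compound 4 (`Cc1ccc(NC(=O)CN2CCN(c3nnc(Cc4ccccc4)c4ccccc34)CC2)c(C)c1`) turns the 2-methylphenyl of compound 2 into 2,4-dimethylphenyl: methyl in place of hydrogen on an aromatic carbon. For the measured compounds named here, the closest precedent is a 5.7-fold higher number from compound 1 to compound 2 (0.76 log units; beyond the scatter), which exchanges the same amide-nitrogen group. The other measured change, a 7.5-fold lower number from compound 2 to compound 3 (0.88 log units; beyond the scatter), lies elsewhere and bears only on how far numbers move in this series. A single added methyl is expected to move the number less than either step, and toward lower values. The expected step is a 2.3-fold lower number from compound 2 to compound 4 (0.35 log units; beyond the scatter). For compound 4 the estimate is 50000 nM, with an expected range of 16000 nM to 130000 nM.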

Compound 4, half-maximal inhibitory concentration: "not active" (no number reported)
No number was reported for compound 4, so the estimate cannot be set against anything.
By their numbers in this assay, from the lowest: compounds 3 and 1 (each within the scatter of the next); then compound 2.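

In this assay, for the compounds shown here, compound 4 is reported as not active without a number, so no step from compound 2 to compound 4 can be read. The compounds shown leave open how far the added methyl of the 2,4-dimethylphenyl group moves the number, and nothing shown speaks to a cause.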